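From dichlorophenyl to difluorophenyl at the assay limit

The source may report more compounds than this note shows. Statements on the series, on what has been measured and on what is new or still open speak of the compounds shown alone.

Measured in a functional assay on MGC-803 cells (Homo sapiens) for cytotoxicity, read by MTT assay, with a stated time of 72 h; a higher number here means a weaker inhibitor, a lower number a stronger inhibitor
- compound 1 `COc1cccc(C=C2C(=O)N(c3ccc(Cl)cc3)N(c3ccc(Cl)cc3)C2=O)c1O` gives 24300 nM
- compound 2 `COc1ccc(C=C2C(=O)N(c3ccc(Cl)cc3)N(c3ccc(Cl)cc3)C2=O)cc1OC` gives > 128000 nM as a limit
- compound 3 `O=C1C(=Cc2ccc(Cl)cc2Cl)C(=O)N(c2ccc(Cl)cc2)N1c1ccc(Cl)cc1` gives > 128000 nM as a limit

Compound 3 has no exact number: its > 128000 nM is a limit. The data show the limit of > 128000 nM in this assay, at which 2 of the 3 values shown sit, and compound 3 is one of those two.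

Compound 4 `O=C1C(=Cc2ccc(F)cc2F)C(=O)N(c2ccc(Cl)cc2)N1c1ccc(Cl)cc1` is still unmeasured. It differs from compound 3 in one place: 2,4-difluorophenyl in place of 2,4-dichlorophenyl on a double-bonded chain carbon bound to a double-bonded ring carbon and the swap sits on a double-bonded chain carbon bound to a double-bonded ring carbon.

Two measured steps changed that same place. One is an at least 5.2-fold higher number from compound 1 to compound 3 (0.72 log units; beyond the scatter) and the other is an at least 5.2-fold higher number from compound 1 to compound 2 (0.72 log units; beyond the scatter) and both lead away from the 2-hydroxy-3-methoxyphenyl group of compound 1. The step that the two limits leave unreadable from compound 2 to compound 3 cannot be sized. Going by the values given here, compound 4 also lacks that group, and no measured step swaps one halogen for another.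

So little change is expected, at most a small move toward a lower number, estimated as an at least 1.1-fold lower number from compound 3 to compound 4 (0.06 log units; that floor lies within the scatter) in this weak range. For compound 4 the expected value is 110000 nM within an estimated range of 35000 nM to 300000 nM. Its measurement may yet give only a limit.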

Compound 4, half-maximal inhibitory concentration: 35700 nM
The estimate for compound 4 lay 3.1-fold (0.49 log units) above the measured number, within the range that was stated.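

In this assay the halogen at this place turns out to matter, with 2,4-difluorophenyl giving an at least 3.5-fold lower number from compound 3 to compound 4 (0.55 log units; beyond the scatter) and, against the dimethoxy compound, an at least 3.5-fold lower number from compound 2 to compound 4 (0.55 log units; beyond the scatter) as well. The 2-hydroxy-3-methoxyphenyl group is therefore not required for an exact reading here, and the step of a 1.5-fold higher number from compound 1 to compound 4 (0.17 log units; within the scatter) does not separate the two groups. Both lower steps give only a floor on the true size, because compound 2 and compound 3 each carry a limit and not a number: the limit of > 128000 nM in this assay, at which 2 of the 4 values shown sit.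

Going by these compounds, it remains open whether this gain is specific to fluorine or would also appear with a plain phenyl group or an aminophenyl group at this place. On these data alone, it is also open whether the two fluorines are both needed.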